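The source may hold more compounds than are shown below. What is called first, only, known or untested is meant among the compounds shown, and "the series" means these compounds.

Measured in a functional assay on U-937 cells (Homo sapiens) for antiproliferative activity, read by MTT assay, with a stated time of 72 h; a lower number here means a stronger inhibitor, a higher number a weaker inhibitor:
compound 1 `O=C(CCCCCCc1nc(-c2ccccc2)no1)C(F)(F)F` gives 410 nM
compound 2 `Cc1ccc(-c2noc(CCCCCCC(=O)C(F)(F)F)n2)cc1` gives 3730 nM
compound 3 `COc1ccc(-c2noc(CCCCCCC(=O)C(F)(F)F)n2)cc1` gives 1170 nM

Compound 3 stands second highest of the three numbers, with compound 1 lower and compound 2 higher. Compound 4 `O=C(CCCCCCc1nc(-c2ccc(C(F)(F)F)cc2)no1)C(F)(F)F` has trifluoromethyl in place of methoxy on an aromatic carbon, para to a large group (trifluoromethyl in place of methoxy on an aromatic carbon). For the measured compounds named here, three measured steps bear on this change. Adding a group gave (a 9.1-fold higher number from compound 1 to compound 2 (0.96 log units; beyond the scatter)) and (a 2.9-fold higher number from compound 1 to compound 3 (0.46 log units; beyond the scatter)), while exchanging one group for another gave (a 3.2-fold lower number from compound 2 to compound 3 (0.50 log units; beyond the scatter)). Trifluoromethyl itself is untested in this series, so the direction remains open. A small rise is expected, probably not beyond the scatter (a 1.3-fold higher number from compound 3 to compound 4 (0.11 log units; within the scatter)). Compound 4 is expected at 1500 nM (estimated range 450 nM to 4500 nM).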

Compound 4, half-maximal inhibitory concentration: 1960 nM
Compound 4: middle estimate off by 1.3-fold (0.12 log units), on the low side; low and high end bracket the measured number.
By their numbers in this assay, from the lowest: compound 1; then compounds 3, 4 and 2 (each within the scatter of the next, the first and the last beyond it).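

In this assay, trifluoromethyl on this aromatic carbon, para to a large group, cannot be separated from methoxy (a 1.7-fold higher number from compound 3 to compound 4 (0.22 log units; within the scatter)) or from methyl (a 1.9-fold lower number from compound 2 to compound 4 (0.28 log units; within the scatter)), although methyl and methoxy differ beyond the scatter. Hydrogen stays apart from it (a 4.8-fold higher number from compound 1 to compound 4 (0.68 log units; beyond the scatter)), so all three groups tested here give higher numbers than hydrogen in compound 1. No supporting measurement explains this result.

Open, from the compounds shown here alone, is whether fluorine, a hydroxyl or an amine on this carbon would give a number as low as that of compound 1, or a lower one.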